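Trifluoromethyl to Trifluoromethoxy: A Small Step Expected

A few compounds are considered here, and "the series" means these few. Any claim that something is new, unique, unknown or untested is made for them only; others in the source may bear on it.

Compound 1 `Cc1n[nH]c(C(=O)O)c1Cc1cccc(-c2ccccc2F)c1` and compound 2 `Cc1n[nH]c(C(=O)O)c1Cc1cccc(C(F)(F)F)c1` share a common core and differ only at one aromatic carbon. In an assay on isolated protein for inhibition of 2-Hydroxyacid oxidase 2 (Homo sapiens), tested at 1 uM (on this read-out lower numbers stand for a weaker effect and higher numbers for a stronger effect at the one concentration tested), compound 1 gives 5%, and compound 2 gives 5%. The step of no change at the digits printed from compound 1 to compound 2 (within the scatter) shows that the exchange left the read-out where it was, so compound 2 stands level with compound 1 on these numbers, both at a low level of effect. Compound 3 `Cc1n[nH]c(C(=O)O)c1Cc1cccc(OC(F)(F)F)c1` is the next move from compound 2: trifluoromethoxy in place of trifluoromethyl on an aromatic carbon. Going by the values given here, only the step from compound 1 to compound 2 bears on this change, and it was flat, so the weak effect of compound 2 at 5% gives no reason to expect movement beyond the scatter in either direction. Compound 3 is therefore expected to give 5%, within a range of 0% to 15%. The expected step is no change at the digits printed from compound 2 to compound 3 (within the scatter).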

Compound 3, a percentage reported as inhibition, at one concentration (the size of the read-out at that concentration, not a potency): 2%
Estimate against measurement, compound 3: 3 percentage points above; measured number inside the range.
By their numbers in this assay, from the lowest: compounds 3, 1 and 2 (each within the scatter of the next).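

In this assay the oxygen-bearing trifluoromethoxy group in place of trifluoromethyl gives a number 3 percentage points lower from compound 2 to compound 3 (within the scatter) and so leaves the read-out at the same low level. Set against the 2-fluorophenyl group, the same exchange gives a number 3 percentage points lower from compound 1 to compound 3 (within the scatter) and extends the flat picture at this aromatic carbon, meta to a large group, to three groups: 2-fluorophenyl, trifluoromethyl and trifluoromethoxy. Nothing available here accounts for this flat result.

Going by these compounds, whether a group of another kind on this carbon, such as an amine or a nitrile, would lift the read-out beyond the scatter remains open. Also open, on these data alone, is whether these three compounds differ at all, since a single concentration with effects this small cannot separate them.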